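The compounds below may be only part of what the source reports. "The series", "measured", "known", "first", "only" and "open" are said of these compounds alone.

In an ADME assay on L6 cells (Rattus norvegicus) for cytotoxicity, read by resazurin assay, with a stated time of 72 h (a lower number here means a stronger inhibitor, a higher number a weaker inhibitor), compound 1 `OC(c1ccc(Cl)cc1)(c1ccc(C(F)(F)F)cc1)c1cccnc1` gives 56400 nM. Compound 2 `OC(c1ccc(Cl)cc1)(c1cccnc1)c1ccc(Cl)cc1F` gives 59400 nM, and the two values lie within the usual scatter of each other. Compound 3 `NC(=O)c1ccc(C(O)(c2ccc(C(F)(F)F)cc2)c2cccnc2)cc1` has no number, only the limit > 100000 nM. From the compounds shown here alone, it stands at the limit of > 100000 nM in this assay, at which 1 of the 3 values shown sits, so how far it lies from the other two is unknown.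

Compound 4 `OC(c1ccc(C(F)(F)F)cc1)(c1cccnc1)c1ccc(Cl)cc1F` has yet to be measured. It is reached from compound 3 by placing 4-chloro-2-fluorophenyl where 4-carbamoylphenyl stood, on a saturated chain carbon bound to two aromatic carbons and an oxygen on a saturated carbon: 4-chloro-2-fluorophenyl in place of 4-carbamoylphenyl on a saturated chain carbon bound to two aromatic carbons and an oxygen on a saturated carbon. For the measured compounds named here, the one measured step that involves a carbamoyl group is an at least 1.7-fold higher number from compound 1 to compound 3 (0.24 log units; that floor lies within the scatter), where carbamoyl replaces chloro on an aromatic carbon. Its floor lies within the scatter, so it gives only weak guidance on size, though it does point towards a lower number once the carbamoyl group has gone. Compound 2, at 59400 nM, carries the entering 4-chloro-2-fluorophenyl group and offers the nearest reference value. A number close to those of compound 1 and compound 2 is therefore expected, with the limit no longer reached. The estimated change is an at least 2.0-fold lower number from compound 3 to compound 4 (0.30 log units; that floor lies within the scatter). For compound 4 the expected value is 50000 nM, within an estimated range of 25000 nM to 95000 nM.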

Compound 4, half-maximal inhibitory concentration: > 100000 nM
Compound 4 ended at the assay's limit (the forecaster's own chance of this, stated with the estimate: 15%); middle value at least 2.0-fold (0.30 log units) from the limit.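

In this assay compound 4, which carries no carbamoyl group, has only a limit, as compound 3 does, so among the compounds shown that group is not needed for a value to sit at the limit, and the step between these two compounds cannot be read: the limit of > 100000 nM in this assay, at which 2 of the 4 values shown sit. The two readable steps are an at least 1.6-fold higher number from compound 2 to compound 4 (0.22 log units; that floor lies within the scatter), with trifluoromethyl in place of chloro on an aromatic carbon, and an at least 1.7-fold higher number from compound 1 to compound 4 (0.24 log units; that floor lies within the scatter), with fluoro in place of hydrogen on an aromatic carbon. Both floors lie within the scatter, so neither single change can be said to raise the number, although compound 4 is the first compound shown to combine the trifluoromethyl and 4-chloro-2-fluorophenyl groups and it reaches the limit.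

From the compounds shown here alone, how far compound 3 and compound 4 actually lie from compound 1 and compound 2 remains unknown, as does whether the two groups together add anything beyond the scatter. Also open, going by these compounds, is what an amine or a carboxylic acid would give in place of the chloro on an aromatic carbon of the core of compound 1.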